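The source may hold more compounds than are shown below. What is called first, only, known or untested is meant among the compounds shown, and "the series" means these compounds.

Working notes on the series. Compound 1 `CCOC(=O)c1c(O)c2cccnc2n(-c2ccccc2)c1=O` carries an ethoxy on a carbonyl carbon of the shared core. In a functional assay on the whole organism for inhibition, with Rattus norvegicus as the target, read by paw edema, at a dose of 100 mg/kg by the oral route (on this read-out higher numbers stand for more inhibition at the one dose given (going by the name of the read-out) and lower numbers for less inhibition), compound 1 gives 23.5%, the highest of the three numbers in hand. Compound 2 `Cc1cccc(NC(=O)c2c(O)c3cccnc3n(-c3ccccc3)c2=O)c1` gives 14.2% and compound 3 `COc1cccc(NC(=O)c2c(O)c3cccnc3n(-c3ccccc3)c2=O)c1` gives 5.7%. The steps between them: a number 9.3 percentage points lower from compound 1 to compound 2 (within the scatter); a number 17.8 percentage points lower from compound 1 to compound 3 (beyond the scatter); a number 8.5 percentage points lower from compound 2 to compound 3 (within the scatter). Both amides made from the ethoxy ester therefore sit lower than compound 1, one within the scatter and one modestly beyond it, while the two amides are within the scatter of each other.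

Compound 4 `O=C(Nc1cccc(Cl)c1)c1c(O)c2cccnc2n(-c2ccccc2)c1=O` is a third amide of the same kind. Its change from compound 1 is (3-chlorophenyl)amino in place of ethoxy on a carbonyl carbon. Among the measured compounds shown here, the steps that bear on it are those from compound 1 to compound 2 and from compound 1 to compound 3, each exchanging the ethoxy for an (aryl)amino group on the same carbonyl carbon; both run downward, by a small to modest amount. A downward step of comparable size is expected here, a number 12.5 percentage points lower from compound 1 to compound 4 (beyond the scatter), with nothing in the numbers to single out the (3-chlorophenyl)amino case as different. Compound 4 is thus estimated at 11%, within the range 0% to 25%.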

Compound 4, a percentage reported as inhibition, in the whole organism at one dose (the size of the read-out at that dose, not a potency): 7.6%
The estimate for compound 4 lay 3.4 percentage points above the measured number; low and high end bracket the measured number.
By their numbers in this assay, from the lowest: compounds 3, 4, 2 and 1 (each within the scatter of the next, the first and the last beyond it).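

The exchange of ethoxy for (3-chlorophenyl)amino on a carbonyl carbon gives a number 15.9 percentage points lower from compound 1 to compound 4 (beyond the scatter) in this assay, so two of the three amides now stand clear of the ester compound 1, while the step to compound 2 remains within the scatter. The identity of the group on the aromatic carbon of the anilide ring makes no readable difference among the three amides: chloro in place of methoxy gives a number 1.9 percentage points higher from compound 3 to compound 4 (within the scatter) and chloro in place of methyl gives a number 6.6 percentage points lower from compound 2 to compound 4 (within the scatter). Nothing at hand explains why the amides tend to sit under the ester, and with only one dose in one whole-animal read-out the numbers record the size of the effect and no more.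

The compounds shown leave open whether the lower numbers go with the amide link itself or with the aryl ring it brings, which an ethylamino group on the same carbonyl carbon would help to separate. They also leave open how a free carboxylic acid or a longer ester chain such as butoxy would compare with the ethoxy of compound 1.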